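Ring-nitrogen position in the anilide series: compound 2 to 3

The source may hold more compounds than are shown below. What is called first, only, known or untested is meant among the compounds shown, and "the series" means these compounds.

Of the compounds shown here, two of the shared core have numbers so far. Compound 1 `COc1cc2c(cc1OC)C(CC(=O)Nc1ccc(Cl)cc1)CC2` gives 71.9% in a functional assay on the whole organism (strain Wistar) for inhibition, with Rattus norvegicus as the target, read by paw edema, with a stated time of 1 h, at a dose of 100 mg/kg; a higher number here means more inhibition at the dose given (going by the name of the read-out), a lower number less inhibition. For the measured compounds named here, compound 2 `COc1cc2c(cc1OC)C(CC(=O)Nc1ccccn1)CC2` gives 25% in this assay and stands lowest of the two, the only step to it being a number 46.9 percentage points lower from compound 1 to compound 2 (beyond the scatter). Compound 3 `COc1cc2c(cc1OC)C(CC(=O)Nc1cccnc1)CC2` is not yet measured; its difference from compound 2 is pyridin-3-yl in place of pyridin-2-yl on an amide-type nitrogen. Going by the values given here, no measured step covers a move of the ring nitrogen within the pyridinyl; the single step in hand concerns the exchange of 4-chlorophenyl for pyridin-2-yl and says nothing about pyridin-3-yl. The two heterocycles count the same atoms, so the working expectation for compound 3 is a small upward step, a number 10 percentage points higher from compound 2 to compound 3 (within the scatter), that need not exceed the scatter. Compound 3 is therefore estimated at 35% in this assay, with a range from 15% to 60%.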

Compound 3, a percentage reported as inhibition, in the whole organism at one dose (the size of the read-out at that dose, not a potency): 25%
Beside the measured number, compound 3's estimate is 10 percentage points above it; the range from low to high includes it.
By their numbers in this assay, from the lowest: compounds 2 and 3 (each within the scatter of the next); then compound 1.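

Moving the ring nitrogen, with pyridin-3-yl in place of pyridin-2-yl on the amide-type nitrogen, gives no change at the digits printed from compound 2 to compound 3 (within the scatter) in this assay, so this read-out at this dose does not separate the two pyridinyl groups. The exchange of 4-chlorophenyl for pyridin-3-yl gives a number 46.9 percentage points lower from compound 1 to compound 3 (beyond the scatter), matching a number 46.9 percentage points lower from compound 1 to compound 2 (beyond the scatter), so the large step is not particular to pyridin-2-yl. No supporting data bear on why the numbers fall this way.

Open, from the compounds shown here alone, is whether the chlorine or the ring nitrogen carries the gap to compound 1, which a plain phenyl group on the same amide-type nitrogen would address. A chloropyridinyl group would show whether chlorine on the ring lifts the number when the ring nitrogen is present.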